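From 3-bromophenyl to 4-(trifluoromethyl)phenyl on the shared core

A few compounds are considered here, and "the series" means these few. Any claim that something is new, unique, unknown or untested is made for them only; others in the source may bear on it.

Among the measured compounds shown here, compound 1 `COc1cc2ncnc(Nc3cccc(Br)c3)c2cc1OCCCCC(=O)Nc1ccc(S(N)(=O)=O)cc1` holds the only number in a functional assay on NCI-H1975 cells (Homo sapiens) for antiproliferative activity, read by MTT assay, with a stated time of 72 h (a lower number here means a stronger inhibitor, a higher number a weaker inhibitor), where compound 1 gives 11400 nM. Compound 2 `COc1cc2ncnc(Nc3ccc(F)cc3)c2cc1OCCCCC(=O)Nc1ccc(S(N)(=O)=O)cc1` reaches only a limit of this assay, > 40000 nM. For the measured compounds named here, the single measured step, an at least 3.5-fold higher number from compound 1 to compound 2 (0.54 log units; beyond the scatter), is thus read against (the limit of > 40000 nM in this assay, at which 1 of the 2 values shown sits). Compound 3 `COc1cc2ncnc(Nc3ccc(C(F)(F)F)cc3)c2cc1OCCCCC(=O)Nc1ccc(S(N)(=O)=O)cc1` differs from compound 1 by 4-(trifluoromethyl)phenyl in place of 3-bromophenyl on a nitrogen on an aromatic ring. That step is the nearest guide, since 4-fluorophenyl and 4-(trifluoromethyl)phenyl both replace 3-bromophenyl. A weakening of comparable size is expected, a 3.1-fold higher number from compound 1 to compound 3 (0.49 log units; beyond the scatter). Compound 3 is accordingly estimated at 35000 nM, within 12000 nM to 100000 nM, with a real chance of a limit only.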

Compound 3, half-maximal inhibitory concentration: 12000 nM
Beside the measured number, compound 3's estimate is 2.9-fold (0.46 log units) above it, and the stated range covers the measured number.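

Swapping 3-bromophenyl for 4-(trifluoromethyl)phenyl on the nitrogen gives no change beyond the scatter in this assay, with a 1.1-fold higher number from compound 1 to compound 3 (0.02 log units; within the scatter). Trifluoromethyl in place of fluoro on an aromatic carbon gives an at least 3.3-fold lower number from compound 2 to compound 3 (0.52 log units; beyond the scatter), so the loss at compound 2 does not extend to every replacement of 3-bromophenyl. The value of compound 2 in that step is a limit, not a number: the limit of > 40000 nM in this assay, at which 1 of the 3 values shown sits.

On these data alone, whether a phenyl ring bearing a methoxy group or an amine would group with compound 1 and compound 3 or with compound 2 remains open.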